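Methyl on the sulfonyl phenyl, tested across two cores

This account rests on a few compounds, and the source may have more. Where it says the series, first, only, none or still open, it means among the compounds named here.

Compound 1 `O=C1/C(=C/c2ccncc2)CN(S(=O)(=O)c2ccccc2)C/C1=C\c1ccccc1F` gives 5800 nM in a functional assay on HepG2 cells (Homo sapiens) for cytotoxicity, read by MTT assay, with a stated time of 24 h; on this read-out higher numbers stand for weaker inhibition and lower numbers for stronger inhibition. Compound 2 `Cc1ccc(S(=O)(=O)N2C/C(=C\c3ccncc3)C(=O)/C(=C/c3ccccc3F)C2)cc1` differs from it by methyl in place of hydrogen on an aromatic carbon, and in this assay compound 2 gives 9700 nM, so that a 1.7-fold higher number from compound 1 to compound 2 (0.22 log units; within the scatter). Compound 3 `O=C1/C(=C/c2cccnc2)CN(S(=O)(=O)c2ccccc2)C/C1=C\c1ccccc1C(F)(F)F` has a different core; the difference between the two cores is not broken down here. In this assay compound 3 gives 5370 nM. Compound 4 `Cc1ccc(S(=O)(=O)N2C/C(=C\c3cccnc3)C(=O)/C(=C/c3ccccc3C(F)(F)F)C2)cc1` is not yet measured. It differs from compound 3 by methyl in place of hydrogen on an aromatic carbon, the same change as that from compound 1 to compound 2, at the same place on the ring. Within the data shown here, for compound 4 the expected step is a 1.7-fold higher number from compound 3 to compound 4 (0.22 log units; within the scatter), set beside a 1.7-fold higher number from compound 1 to compound 2 (0.22 log units; within the scatter) as the only earlier pair and resting on nothing else. For compound 4 in this assay the estimate is 9000 nM, expected to fall between 4500 nM and 18000 nM.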

Compound 4, half-maximal inhibitory concentration: 2930 nM
Compound 4: middle estimate off by 3.1-fold (0.49 log units), on the high side, and the stated range ends above it.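

In this assay, methyl in place of hydrogen on the phenylsulfonyl group gives a 1.8-fold lower number from compound 3 to compound 4 (0.26 log units; within the scatter) and, although each step alone stays within the scatter, the two cores do not agree: the same change on two cores in this assay, a 1.7-fold higher number (0.22 log units; within the scatter) from compound 1 to compound 2 and a 1.8-fold lower number (0.26 log units; within the scatter) from compound 3 to compound 4, 3.1-fold (0.49 log units) apart, beyond the scatter of two such steps

The step seen on the core of compound 1 therefore cannot be carried to the core of compound 3 as a fixed increment. Among these compounds, with only one pair per core, this does not show which difference between the cores matters, or how the change would read on any further core.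

Still open, as far as these compounds go, is whether a chlorine atom, a methoxy group or an amine in place of the methyl would also give steps that differ between these two cores.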